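Chain length and terminal aryl in a hydroxamate series

The source may report more compounds than this note shows. Statements on the series, on what has been measured and on what is new or still open speak of the compounds shown alone.

Of the compounds shown here, two have been measured in an assay on isolated protein for inhibition of histone deacetylase 8 (Homo sapiens); a higher number here means a weaker inhibitor, a lower number a stronger inhibitor. Compound 1 `O=C(CCCCCC(=O)c1ccccc1)NO` gives 1500 nM. Compound 2 `O=C(CCCCCCCC(=O)c1ccccc1)NO`, which carries a longer chain, gives 65 nM. Among the measured compounds shown here, the only step so far, a 23-fold lower number from compound 1 to compound 2 (1.36 log units; beyond the scatter), is a chain-lengthening, and it leaves compound 2 with the lowest of the two numbers, its nearest neighbour being compound 1 at a markedly higher value.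

Compound 3 `O=C(CCCCCCCC(=O)c1ccc(-c2ccccc2)cc1)NO` keeps the chain of compound 2 and alters only the aromatic end: phenyl in place of hydrogen on an aromatic carbon. For the measured compounds named here, no measured step touches the aromatic ring; the single step that is known concerns the chain and therefore does not bear directly on this change. With nothing measured to anchor the effect of the added phenyl, no shift beyond the scatter is expected in this assay, and the estimate for compound 3 is set close to compound 2, as a 1.3-fold lower number from compound 2 to compound 3 (0.11 log units; within the scatter). Compound 3 is thus expected to give about 50 nM, within a range from 15 nM to 200 nM.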

Compound 3, half-maximal inhibitory concentration: 5 nM
For compound 3 the middle estimate is 10-fold (1.00 log units) above the measured one; measured number outside the range, below it.
By their numbers in this assay, from the lowest: compound 3; then compound 2; then compound 1.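

In this assay the aromatic end proves to be a responsive position: phenyl in place of hydrogen on an aromatic carbon, para to a large group, gives a 13-fold lower number from compound 2 to compound 3 (1.11 log units; beyond the scatter). Until now only the chain had been seen to move the number, whereas compound 3 keeps the chain of compound 2 and still yields a large step, of the same printed class as a 23-fold lower number from compound 1 to compound 2 (1.36 log units; beyond the scatter). Nothing at hand bears on why the added phenyl shifts the number this far.

Still open, going by these compounds, is whether the gain calls for a second aromatic ring at this place, which a cyclohexyl, a methoxy or a chlorine on the same aromatic carbon would help to settle, and whether a phenoxy or benzyl group, or a pyridyl ring in place of the added phenyl, would hold the step. Also open, on these data alone, is whether the phenyl step carries over to the shorter chain of compound 1 or to a chain longer than that of compound 2, since the two changes have so far been seen only one at a time.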